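A few compounds are considered here, and "the series" means these few. Any claim that something is new, unique, unknown or untested is made for them only; others in the source may bear on it.

Measured so far:
- compound 2, `C[Se]c1nc(NCc2ccccc2)c2ccccc2n1`: 570 nM
- compound 1, `CCCCC[Se]c1nc(NCc2ccc(SC)cc2)c2ccccc2n1`: 34700 nM

In an ADME assay on BEAS-2B cells (Homo sapiens) for cytotoxicity, read by MTT assay, with a stated time of 72 h (on this read-out higher numbers stand for weaker inhibition of growth and lower numbers for stronger inhibition of growth), compound 2 stands at the lowest of the two numbers, and compound 1 sits far above it, beyond the usual scatter. Compound 3, `CSc1ccc(CNc2nc([Se]C)nc3ccccc23)cc1`, differs from compound 2 by methylsulfanyl in place of hydrogen on an aromatic carbon. For the measured compounds named here, no measured pair isolates this one change; compound 1 carries the same methylsulfanyl group, but also a different chain on selenium, so it offers only a loose hint. The expected step of a 3.5-fold higher number from compound 2 to compound 3 (0.55 log units; beyond the scatter) is toward weaker growth inhibition, probably just beyond the scatter. Compound 3 is estimated at 2000 nM, within 400 nM to 15000 nM.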

Compound 3, concentration for 50% growth inhibition: 35900 nM
For compound 3 the middle estimate is 18-fold (1.25 log units) below the measured one, and the stated range ends below it.
By their numbers in this assay, from the lowest: compound 2; then compounds 1 and 3 (each within the scatter of the next).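

In this assay, methylsulfanyl in place of hydrogen on this aromatic carbon, para to a large group, brings a large shift toward weaker growth inhibition: a 63-fold higher number from compound 2 to compound 3 (1.80 log units; beyond the scatter). With methylsulfanyl present, swapping hydrogen for butyl on the chain bound to selenium leaves the two values within the scatter: a 1.0-fold higher number from compound 1 to compound 3 (0.01 log units; within the scatter). Nothing available gives a reason for the large step. As far as these compounds go, whether a methoxy group or a chlorine atom on the same carbon would give a similar step remains open, as does whether the chain on selenium matters when methylsulfanyl is absent.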